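The source may report more compounds than this note shows. Statements on the series, on what has been measured and on what is new or still open speak of the compounds shown alone.

Of the compounds shown here, three built on a shared core have so far been tested in a functional assay on the whole organism with Rattus norvegicus as the target, at a dose of 20 mg/kg by the intraperitoneal route; a higher number here means more inhibition at the dose given (going by the name of the read-out), a lower number less inhibition. Compound 1 `CCc1ccccc1-c1nc(N)nc(N)n1` gives 20% in this assay. Compound 2 `CS(=O)(=O)c1cccc(-c2nc(N)nc(N)n2)c1` gives -6%, and compound 3 `Nc1nc(N)nc(-c2cc(Br)ccc2Br)n1` gives 43%. On these numbers compound 1 stands second highest of the three: its nearest neighbour is compound 3, which lies higher by a margin beyond the usual scatter, and furthest from it is compound 2, lower by a margin that is also beyond the scatter.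

Compound 4 `Nc1nc(N)nc(-c2ccccc2Cl)n1` has not yet been measured. It differs from compound 1 in a single place: chloro in place of ethyl on an aromatic carbon. Going by the values given here, no pair of measured compounds shows this exact change, so there is no measured step to lean on; only the three values above and the nature of the change can guide an expectation. Because compound 3 with its bromo groups gives 43% while compound 1 with its ethyl gives 20%, a small rise, or no change beyond the scatter, seems the likeliest outcome for swapping in a halogen. The expected step of a number 8 percentage points higher from compound 1 to compound 4 (within the scatter) is accordingly modest and upward. Compound 4 is therefore estimated to give 28% in this assay, with a plausible range from 5% to 50%.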

Compound 4, a percentage reported as inhibition, in the whole organism at one dose (the size of the read-out at that dose, not a potency): 36%
For compound 4 the middle estimate is 8 percentage points below the measured one, within the range that was stated.
By their numbers in this assay, from the lowest: compound 2; then compound 1; then compounds 4 and 3 (each within the scatter of the next).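

In this assay, putting chloro in place of ethyl on an aromatic carbon, ortho to a group of 8 heavy atoms, gives a number 16 percentage points higher from compound 1 to compound 4 (beyond the scatter). Going by these compounds alone, this is the only change so far that can be read on its own, since the earlier compounds are not one change apart, and it shows that at this place the number rises when the ethyl, with its 2 heavy atoms, gives way to a single chlorine atom. Nothing available bears on the reason for this rise.

A single step cannot tell whether the rise belongs to chloro in particular or would also appear with other groups at this place, such as fluoro, methyl, methoxy or an amine. On these data alone, it also remains open whether a longer chain such as propyl would fall below compound 1, and whether chloro in place of ethyl would have the same effect at a different dose, as this read-out reflects a single dose and is not a potency.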